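The source may hold more compounds than are shown below. What is called first, only, known or untested is meant among the compounds shown, and "the series" means these compounds.

Measured so far: compound 1 `Cc1ccc(NC(=O)c2ccc(CN3CCCN(C)CC3)cc2)cc1-n1cc(-c2cnc3ccnn3c2)cn1` gives 5880 nM; compound 2 `COc1ccc(C(=O)Nc2ccc(C)c(-n3cc(-c4cnc5ccnn5c4)cn3)c2)cc1` gives 19700 nM; compound 3 `Cc1ccc(NC(=O)c2ccc(F)cc2)cc1-n1cc(-c2cnc3cccnn23)cn1` gives 12400 nM, all in a functional assay on K562 cells (Homo sapiens) for antiproliferative activity, read by CCK-8 assay, with a stated time of 24 h; a higher number here means a weaker inhibitor, a lower number a stronger inhibitor.

Compound 3 has the second highest number of the three. Its nearest neighbour is compound 2, within the scatter; compound 1 gives a lower number, beyond the scatter. Among the measured compounds shown here, compound 3 differs from compounds 1 and 2 in more than one place, so no single step leads to it.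

Compound 4 `CCc1ccc(C(=O)Nc2ccc(C)c(-n3cc(-c4cnc5cccnn45)cn3)c2)cc1` differs from compound 3 by ethyl in place of fluoro on an aromatic carbon. For the measured compounds named here, the one measured step, a 3.4-fold higher number from compound 1 to compound 2 (0.53 log units; beyond the scatter), also swaps a group at this position of the benzamide, and it was modest. The ethyl for fluoro exchange is expected to give a step of about a 1.1-fold lower number from compound 3 to compound 4 (0.05 log units; within the scatter), if any, and compound 4 is expected at 11000 nM, between 4500 nM and 28000 nM.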

Compound 4, half-maximal inhibitory concentration: 7540 nM
Beside the measured number, compound 4's estimate is 1.5-fold (0.16 log units) above it; the range from low to high includes it.
By their numbers in this assay, from the lowest: compounds 1, 4, 3 and 2 (each within the scatter of the next, the first and the last beyond it).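

In this assay, the exchange of fluoro for ethyl on this aromatic carbon gives a 1.6-fold lower number from compound 3 to compound 4 (0.22 log units; within the scatter). Among the compounds shown here, this is the first step read on the core of compound 3, and it shows that going from 4-fluorophenyl to 4-ethylphenyl leaves no difference that can be told from the scatter. Nothing shown gives a reason for this result.

On these data alone, what an amine or a carboxylic acid at this position would do on this core remains open. So does whether a longer chain in place of ethyl would move the number beyond the scatter.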